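Series notes: chloro for methyl on the aryl ring

The source may hold more compounds than are shown below. What is called first, only, known or untested is meant among the compounds shown, and "the series" means these compounds.

Measured so far:
compound 1 `C#CCSc1nc(Sc2nc3ccccc3s2)c(C#N)c(-c2cc(OC)c(OC)c(OC)c2)n1` — > 20000 nM
compound 2 `C#CCSc1nc(Sc2nccs2)c(C#N)c(-c2ccc(C)cc2)n1` — 4300 nM
compound 3 `C#CCSc1nc(Sc2nc[nH]n2)c(C#N)c(-c2cc(OC)c(OC)c(OC)c2)n1` — > 20000 nM

In a functional assay on KYSE-70 cells for antiproliferative activity against KYSE-70 cell line (Homo sapiens), read by MTT assay, with a stated time of 72 h (on this read-out higher numbers stand for weaker inhibition and lower numbers for stronger inhibition), compound 1 gives > 20000 nM, which is a limit of the assay and not a number. Compound 3 gives > 20000 nM, likewise a limit. Among the compounds with values here, compound 2 with 4300 nM therefore stands as the only number among the three values shown. Within the data shown here, the one measured step, a step that the two limits leave unreadable from compound 1 to compound 3, cannot be sized because both of its ends sit at the limit of > 20000 nM in this assay, at which 2 of the 3 values shown sit.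

Compound 4 `C#CCSc1nc(Sc2nccs2)c(C#N)c(-c2ccc(Cl)cc2)n1` differs from compound 2 by chloro in place of methyl on an aromatic carbon. Among the measured compounds shown here, no measured step involves this change, and nothing among the three values speaks to it. A step in this assay beyond the scatter is thus not expected in either direction. Compound 4 is estimated at 4000 nM, range 1500 nM to 12000 nM, an expected step of a 1.1-fold lower number from compound 2 to compound 4 (0.03 log units; within the scatter).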

Compound 4, half-maximal inhibitory concentration: 5350 nM
The estimate for compound 4 lay 1.3-fold (0.13 log units) below the measured number; low and high end bracket the measured number.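

In this assay the change from 4-methylphenyl to 4-chlorophenyl gives a 1.2-fold higher number from compound 2 to compound 4 (0.09 log units; within the scatter) and so, for this pair, the position on the aromatic carbon takes chloro in place of methyl with no step beyond the scatter. Within the data shown here, this is the first readable step, and it concerns the aryl group, not the group on sulfur. Nothing at hand gives a reason for this result. As far as these compounds go, what an amine, a carboxylic acid or a butyl chain at this place would do remains open.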